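The compounds below may be only part of what the source reports. "The series", "measured", "known", "first", "only" and "open" are said of these compounds alone.

Measured in a functional assay on MCF7 cells (Homo sapiens) for inhibition, read by MTT assay (on this read-out higher numbers stand for weaker inhibition and lower numbers for stronger inhibition), so far
Compound 1 `COc1ccc2cc(-c3ccc(C(F)(F)F)cc3)c(=O)oc2c1CCC(C)C` gives 24500 nM
Compound 2 `CC(C)CCc1c(O)ccc2cc(-c3ccc(OC(F)(F)F)cc3)c(=O)oc12` gives 5700 nM
Compound 3 `COc1ccc2c(Oc3ccc4ccc(=O)oc4c3CCC(C)C)cc(=O)oc2c1` gives > 50000 nM

Compound 3 stands at > 50000 nM as a limit of the assay, not as a number. Compound 4 `CC(C)CCc1c(Oc2cc(=O)oc3cc(O)ccc23)ccc2ccc(=O)oc12` differs from it by one change, hydrogen in place of methyl on an oxygen on an aromatic ring with methoxy going to hydroxy. Going by the values given here, no measured pair shows this change alone. Compound 2, with a hydroxy group, gives 5700 nM and compound 1, with a methoxy group, gives 24500 nM but these two also differ in another group. On that slender basis, a modest move toward stronger inhibition in this assay is expected, and the estimated at least 1.7-fold lower number from compound 3 to compound 4 (0.25 log units; that floor lies within the scatter) is read in that light. Compound 4 is estimated at 28000 nM with an expected range from 12000 nM to 50000 nM in this measurement.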

Compound 4, half-maximal inhibitory concentration: > 50000 nM
Compound 4: only a limit was reported; the forecaster's own chance of this, stated with the estimate: 35%; middle value at least 1.7-fold (0.25 log units) away from the limit.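

Going by these compounds alone, compound 3 and compound 4 both stand at a limit of this assay, not at a number, so no step between them can be read: the limit of > 50000 nM in this assay, at which 2 of the 4 values shown sit.
What methoxy to hydroxy does on its own, with nothing else changing, stays open among the compounds shown.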